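A few compounds are considered here, and "the series" means these few. Any claim that something is new, unique, unknown or untested is made for them only; others in the source may bear on it.

Working notes on the aryl hydrazone series sharing the core of compound 1 `COc1cc(/C=N/NC(=O)Nc2ccc(Oc3ccnc(-c4nncn4CCN(C)C)c3)c(F)c2)cc(OC)c1OC`. In a functional assay on U-87MG ATCC cells (Homo sapiens) for cytotoxicity, read by MTT assay, with a stated time of 72 h (on this read-out lower numbers stand for stronger inhibition and higher numbers for weaker inhibition), compound 1 gives 22500 nM. Compound 2 `CN(C)CCn1cnnc1-c1cc(Oc2ccc(NC(=O)N/N=C/c3cccc(Br)c3)cc2F)ccn1` gives 830 nM and compound 3 `CN(C)CCn1cnnc1-c1cc(Oc2ccc(NC(=O)N/N=C/c3ccc(Cl)cc3)cc2F)ccn1` gives 1370 nM. Compound 3 thus stands second highest of the three numbers; its nearest neighbour is compound 2, separated by a 1.7-fold higher number from compound 2 to compound 3 (0.22 log units; within the scatter), while compound 1 lies furthest, separated by a 16-fold lower number from compound 1 to compound 3 (1.22 log units; beyond the scatter).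

Compound 4 `CN(C)CCn1cnnc1-c1cc(Oc2ccc(NC(=O)N/N=C/c3ccc(O)c(F)c3)cc2F)ccn1` differs from compound 3 in one place: 3-fluoro-4-hydroxyphenyl in place of 4-chlorophenyl on a carbon with a double bond to nitrogen. The measured steps that touch this position are the two large drops, a 27-fold lower number from compound 1 to compound 2 (1.43 log units; beyond the scatter) and a 16-fold lower number from compound 1 to compound 3 (1.22 log units; beyond the scatter), and the small step of a 1.7-fold higher number from compound 2 to compound 3 (0.22 log units; within the scatter). The exchange of one halogen for another therefore moved the number little, whereas the exchange of an oxygen-bearing aryl for a halogen-bearing one moved it a great deal. Among the compounds with values here, no measured step introduces a hydroxyl group or a 3-fluoro-4-hydroxyphenyl, so the direction is uncertain; because compound 1, carrying oxygen substituents, gives 22500 nM, a number somewhat higher than that of compound 3 is expected in this assay, with a step of about a 2.0-fold higher number from compound 3 to compound 4 (0.31 log units; beyond the scatter). For compound 4 the estimate in this assay is 2800 nM, with a range from 900 nM to 9000 nM.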

Compound 4, half-maximal inhibitory concentration: > 100000 nM
Compound 4: a limit, no number (the forecaster's own chance of this, stated with the estimate: 5%); middle value at least 35-fold (1.55 log units) away from the limit.
By their numbers in this assay, from the lowest: compounds 2 and 3 (each within the scatter of the next); then compound 1. At a limit, above all of these: compound 4.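

In this assay compound 4 stands at a limit of the assay and gives no number: the limit of > 100000 nM in this assay, at which 1 of the 4 values shown sits. Read against that limit, 3-fluoro-4-hydroxyphenyl on a carbon with a double bond to nitrogen gives an at least 72-fold higher number from compound 3 to compound 4 (1.86 log units; beyond the scatter) and an at least 120-fold higher number from compound 2 to compound 4 (2.08 log units; beyond the scatter), so the halogen-bearing aryl groups of the earlier compounds can be lost from at this position by far more than the earlier steps showed. With an at least 4.4-fold higher number from compound 1 to compound 4 (0.64 log units; beyond the scatter), compound 1 no longer marks the high end of the series, and among these four compounds both aryl groups bearing oxygen sit above both aryl groups bearing only a halogen, with no compound going against this.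

The hydroxyl and the fluorine enter together in compound 4, so the compounds shown do not separate the share of each, and a phenyl carrying the hydroxyl alone or the fluorine alone would be needed to do so. Also open, from the compounds shown here alone, is whether an amine or a carboxylic acid in place of the hydroxyl would give a measurable number in this assay, and how far past its limit compound 4 lies.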